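A few compounds are considered here, and "the series" means these few. Any claim that something is new, unique, unknown or untested is made for them only; others in the source may bear on it.

Measured so far in a toxicity assay on HT-29 cells (Homo sapiens) for cytotoxicity; a higher number here means that more compound is tolerated, a lower number that less compound is tolerated:
Compound 1 `CN1C(=S)[C@@H](NC(=O)c2nc(Cc3ccccc3)n(CC3COC3)n2)COc2ccccc21`: > 100000 nM (a limit)
Compound 2 `CN1C(=S)[C@@H](NC(=O)c2nc(Cc3ccccc3)n(C3CCNCC3)n2)COc2ccccc21`: > 100000 nM (a limit)

Compound 2 reads > 100000 nM in this assay and this is a limit, not a number. Compound 1 reads > 100000 nM as a limit too. For the measured compounds named here, the only measured step is a step that the two limits leave unreadable from compound 1 to compound 2 and it gives no size to carry forward. Compound 3 `Cc1cnc(-n2nc(C(=O)N[C@H]3COc4ccccc4N(C)C3=S)nc2Cc2ccccc2)nc1` carries 5-methylpyrimidin-2-yl in place of piperidin-4-yl on an aromatic nitrogen. The expectation rests on compound 2 at > 100000 nM as a limit and on the limit of > 100000 nM in this assay, at which 2 of the 2 values shown sit, as the whole of the evidence. No change beyond the scatter is expected in either direction in this assay and the expected step is a number no higher from compound 2 to compound 3 (the limit leaves the size open) on that basis. Compound 3 is estimated at 100000 nM with an expected range from 30000 nM to 150000 nM and may well turn out to be only a limit.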

Compound 3, half-maximal cytotoxic concentration: > 100000 nM
Compound 3: only a limit was reported (the forecaster's own chance of this, stated with the estimate: 80%); the middle value sits exactly at the limit.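

In this assay compound 3 gives > 100000 nM as a limit and not a number. The steps among compound 1, compound 2 and compound 3 therefore cannot be read: the limit of > 100000 nM in this assay, at which 3 of the 3 values shown sit.

The compounds shown leave open whether changing the group on the aromatic nitrogen alters cytotoxicity, and at what concentration any of them becomes cytotoxic.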